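The source may hold more compounds than are shown below. What is called first, only, known or untested is meant among the compounds shown, and "the series" means these compounds.

Measured so far in a functional assay on CHO cells for agonist activity at Free fatty acid receptor 1 (Homo sapiens), read by FLIPR and calcium flux; on this read-out lower numbers stand for an effect already at smaller amounts and higher numbers for an effect only at larger amounts of compound:
compound 1, `Cc1cc(OCCCS(C)(=O)=O)cc(C)c1-c1cccc(COc2ccc(CCC(=O)O)cc2)c1`, gives 15.5 nM;
compound 2, `Cc1ccccc1-c1cccc(COc2ccc(S(=O)(=O)CC(=O)O)cc2)c1`, gives 46.8 nM;
compound 3, `O=C(O)CS(=O)(=O)c1cccc(OCc2ccc(-c3ccccc3)cc2)c1`, gives only a limit of the assay, > 1000 nM.

Among the two numbers actually measured, compound 2 stands at the higher one, meaning it needs more compound than compound 1 to reach its effect; the gap between compound 1 and compound 2 lies beyond the usual scatter of repeated measurements. Among the compounds with values here, no pair of measured compounds differs in just one place, so there is no directly comparable step to lean on.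

The next compound to be tested is compound 4, `O=C(O)CS(=O)(=O)c1ccc(OCc2cccc(Oc3ccccc3)c2)cc1`. Compared with compound 2 the change is this: phenoxy in place of 2-methylphenyl on an aromatic carbon.

Within the data shown here, no measured step resembles this exchange. The expectation therefore rests on the two numbers alone and on the size of the change itself. A moderate rise in the number, somewhat beyond the scatter, is expected as the step from compound 2 to compound 4, a 3.2-fold higher number from compound 2 to compound 4 (0.51 log units; beyond the scatter). Compound 4 is therefore estimated at 150 nM in this assay, with a likely range from 40 nM to 600 nM.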

Compound 4, half-maximal effective concentration: 97.7 nM
The estimate for compound 4 lay 1.5-fold (0.19 log units) above the measured number; measured number inside the range.
By their numbers in this assay, from the lowest: compound 1; then compound 2; then compound 4. At a limit, above all of these: compound 3.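

In this assay, within the data shown here, the exchange of 2-methylphenyl for phenoxy is the first change in one place that can be read directly, and it gives a 2.1-fold higher number from compound 2 to compound 4 (0.32 log units; beyond the scatter). This shows that an aromatic carbon meta to a large group can carry phenoxy at a modest cost, even though the two groups match in heavy-atom count and each holds one six-membered aromatic ring of carbon only. The entering group differs by its oxygen, which counts as a hydrogen-bond acceptor, and by the loss of the methyl, so this single step ties the higher number to the exchange as a whole and to neither difference alone.

From the compounds shown here alone, it remains open whether the oxygen or the missing methyl accounts for the step, a question that a comparison with benzyl or 2-methylphenoxy in the same place could help to answer. Compound 3 stays outside any such reading, since it differs from the others in more than one place and its value is only a limit: the limit of > 1000 nM in this assay, at which 1 of the 4 values shown sits.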